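The source may report more compounds than this note shows. Statements on the series, on what has been measured and on what is new or still open speak of the compounds shown alone.

Compound 1 `N=C(N)NCCC[C@H](N)C(=O)NS(=O)(=O)OC[C@H]1OC[C@@H](n2cnc3c(N)ncnc32)C[C@@H]1O` is a sulfamate-linked conjugate whose only measured neighbour, compound 2 `N=C(N)NCCC[C@H](N)C(=O)NS(=O)(=O)OC[C@H]1OC[C@@H](n2cnc3c(N)ncnc32)[C@H](O)[C@@H]1O`, differs by a hydroxy in place of hydrogen on a saturated ring carbon. In a functional assay on PBMC cells (Homo sapiens) for inhibition (on this read-out lower numbers stand for stronger inhibition and higher numbers for weaker inhibition), compound 1 gives 600 nM, and compound 2 gives 600 nM; the step of no change at the digits printed from compound 1 to compound 2 (within the scatter) leaves compound 1 level with compound 2. Compound 3 `C[C@H](N)C(=O)NS(=O)(=O)OC[C@H]1OC[C@@H](n2cnc3c(N)ncnc32)C[C@@H]1O` is reached from compound 1 by a hydrogen atom in place of a group of 6 heavy atoms (3 carbon, 3 nitrogen; no ring), on a saturated chain carbon, two bonds along the chain from an amine nitrogen and a carbonyl carbon. Going by the values given here, no measured step touches that chain, so the one known step gives no direct guide. A large loss is expected, a 17-fold higher number from compound 1 to compound 3 (1.22 log units; beyond the scatter), putting compound 3 at an estimated 10000 nM, between 2000 nM and 50000 nM.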

Compound 3, half-maximal inhibitory concentration: 5500 nM
The estimate for compound 3 lay 1.8-fold (0.26 log units) above the measured number; the range from low to high includes it.
By their numbers in this assay, from the lowest: compounds 1 and 2 (each within the scatter of the next); then compound 3.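

Replacing that group of 6 heavy atoms with a hydrogen atom gives a 9.2-fold higher number from compound 1 to compound 3 (0.96 log units; beyond the scatter) in this assay and so shows that this read-out responds to the chain on the saturated carbon, which the earlier ring-carbon step could not show. Compound 3 still gives a measured number without that group, so the group is not needed for a measurable value. Nothing available explains the size of this step.

From the compounds shown here alone, whether an amine or a carboxylic acid at the end of a shorter chain would hold the value of compound 1 remains open. Also open, going by these compounds, is whether the ring hydroxy would matter in compound 3.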